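The compounds below may be only part of what the source reports. "The series", "measured", "known", "first", "only" and "open" are said of these compounds alone.

Measured compounds in a functional assay on the whole organism for inhibition, with Rattus norvegicus as the target; on this read-out lower numbers stand for an effect already at smaller amounts and higher numbers for an effect only at larger amounts of compound:

- compound 1 `CC1CC/C(=N\Nc2cccc(C(=O)O)c2)c2nccc(=O)n21`: in this assay compound 1 gives > 100 umol/kg, a limit of the assay and not a number.
- compound 2 `CC1CC/C(=N\Nc2ccccc2Cl)c2ncc(C(=O)O)c(=O)n21`: compound 2 gives > 1000 umol/kg, again a limit and not a number.
- compound 3 `CC1CC/C(=N\Nc2cccc(Br)c2)c2ncc(C(=O)O)c(=O)n21`: compound 3 gives > 320 umol/kg, also a limit and not a number.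

Compound 3 therefore stands at a limit only (the limit of > 320 umol/kg in this assay, at which 1 of the 3 values shown sits), and the two other values in the series are likewise limits the limit of > 100 umol/kg in this assay, at which 1 of the 3 values shown sits (the limit of > 1000 umol/kg in this assay, at which 1 of the 3 values shown sits); no value in this assay is a true number. Among the measured compounds shown here, the one single-point step in the set, a step that the two limits leave unreadable from compound 2 to compound 3, is left unreadable by its two limits.

Compound 4 `CC1CC/C(=N\Nc2ccc(O)cc2)c2ncc(C(=O)O)c(=O)n21` differs from compound 3 as follows: 4-hydroxyphenyl in place of 3-bromophenyl on an amine nitrogen. For the measured compounds named here, no measured step speaks to this change, since the only one available cannot be read. With compound 3 at a limit and every neighbour at a limit, the expectation for compound 4 is a further limit rather than a number, with the step that the limit leaves unreadable from compound 3 to compound 4 estimated as no change beyond the scatter. Compound 4 is thus estimated at 600 umol/kg, within 150 umol/kg to 3000 umol/kg, in this assay.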

Compound 4, dose for 50% inhibition: > 100 umol/kg
Compound 4 ended at the assay's limit (the forecaster's own chance of this, stated with the estimate: 80%); the middle value lies beyond the limit too.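

Compound 2, compound 3 and compound 4 all stand at limits and not at numbers, so neither new step, to compound 4 from compound 3 or from compound 2, can be read. The compounds shown leave open whether in this assay any compound carrying 2-chlorophenyl, 3-bromophenyl or 4-hydroxyphenyl gives a true number.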